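Swapping the allyl thiourea arm of compound 1 for a succinamic acid

A few compounds are considered here, and "the series" means these few. Any claim that something is new, unique, unknown or untested is made for them only; others in the source may bear on it.

Measured so far:
Compound 1 `C=CCNC(=S)NC1=C(C#N)C(c2ccc(Cl)cc2Cl)C2=C(CCCC2=O)N1c1ccc(S(N)(=O)=O)cc1`: 30%
Compound 2 `N#CC1=C(NC(=S)Nc2ccc(Br)cc2)N(c2ccc(S(N)(=O)=O)cc2)C2=C(C(=O)CCC2)C1c1ccc(Cl)cc1Cl`: 50%

In a functional assay on Ehrlich cells (Mus musculus) for cytotoxicity, read by trypan blue exclusion, with a stated time of 2 h, tested at 25 ug/mL (a higher number here means a stronger effect of the compound at the concentration tested, a lower number a weaker effect), compound 1 gives 30%, the lowest of the two numbers shown. Among the measured compounds shown here, its nearest neighbour is compound 2, which in this assay gives 50%; the only measured step, a number 20 percentage points higher from compound 1 to compound 2 (beyond the scatter), exchanges the group on an amide-type nitrogen.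

Compound 3 `N#CC1=C(NC(=O)CCC(=O)O)N(c2ccc(S(N)(=O)=O)cc2)C2=C(C(=O)CCC2)C1c1ccc(Cl)cc1Cl` is not yet measured. It differs from compound 1 as follows: a group of 7 heavy atoms (4 carbon, 3 oxygen; no ring) in place of a group of 6 heavy atoms (4 carbon, 1 nitrogen, 1 sulfur; no ring), on an amine nitrogen

For the measured compounds named here, the step from compound 1 to compound 2 bears on this change only loosely: it shows that a different group on the same nitrogen can move the read-out by a modest amount beyond the scatter, but the group entering in compound 3 is neither of those two groups, and no measured pair shows a (2-carboxyethyl)carbonyl entering. The direction therefore cannot be read from the data, and the expectation for compound 3 is a step of a number 5 percentage points higher from compound 1 to compound 3 (within the scatter) that is small and uncertain. Compound 3 is estimated at 35%, with a range from 15% to 55% in this assay.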

Compound 3, a percentage reported as activity, at one concentration (the size of the read-out at that concentration, not a potency): 35%
For compound 3 middle estimate and measured number coincide at the digits printed, within the range that was stated.
By their numbers in this assay, from the lowest: compounds 1 and 3 (each within the scatter of the next); then compound 2.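

Placed on the amine nitrogen, the (2-carboxyethyl)carbonyl group shows that the allyl thiourea arm can give way to an arm with a carboxylic acid end and no sulfur with no change that stands clear of the scatter in this assay, as the step of a number 5 percentage points higher from compound 1 to compound 3 (within the scatter) shows. Against the 4-bromophenyl thiourea arm, the same group gives a number 15 percentage points lower from compound 2 to compound 3 (beyond the scatter), so among the three compounds the arm carrying the aromatic ring is the one set apart, while the two arms without a ring cannot be told apart. Nothing available here bears on why these arms read as they do.

As far as these compounds go, whether a methyl ester or a primary amide at the end of the chain would read differently from the carboxylic acid of compound 3 stays open, as does the effect of a longer chain. Also open, from the compounds shown here alone, is whether the bromine of compound 2 or its phenyl ring accounts for its place, which an unsubstituted phenyl or a chlorine in place of the bromine could settle.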